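This account rests on a few compounds, and the source may have more. Where it says the series, first, only, none or still open, it means among the compounds named here.

Of the compounds shown here, three built on one shared core have been tested in a functional assay (Cavia porcellus) with sulfonylurea receptors; K-ATP channels (Homo sapiens) as the target; a higher number here means a weaker inhibitor, a lower number a stronger inhibitor. Compound 1 `CC(O)(C(=O)Nc1ccc(S(=O)(=O)c2cccc(F)c2)cc1)C(F)(F)F` gives 3400 nM, and compound 2 `COc1cccc(S(=O)(=O)c2ccc(NC(=O)C(C)(O)C(F)(F)F)cc2)c1` gives 16000 nM. For compound 3 `CC(O)(C(=O)Nc1ccc(S(=O)(=O)c2ccc(Br)cc2)cc1)C(F)(F)F` this assay reports only a limit, > 30000 nM. Compound 3 therefore stands at the upper edge of the numbers seen, reached through an at least 8.8-fold higher number from compound 1 to compound 3 (0.94 log units; beyond the scatter) and an at least 1.8-fold higher number from compound 2 to compound 3 (0.27 log units; that floor lies within the scatter). Compound 4 `CC(O)(C(=O)Nc1ccc(S(=O)(=O)c2ccccn2)cc1)C(F)(F)F` differs from compound 3 by pyridin-2-yl in place of 4-bromophenyl on a sulfonyl sulfur. Both measured steps raised the number on the way to the 4-bromophenyl group, so moving away from it is expected to lower the number again, by roughly an at least 2.0-fold lower number from compound 3 to compound 4 (0.30 log units; that floor lies within the scatter), though the exact size is uncertain. Compound 4 is thus estimated to give about 15000 nM, within a range from 4000 nM to 60000 nM.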

Compound 4, half-maximal inhibitory concentration: 600 nM
Compound 4: the middle estimate sits 25-fold (1.40 log units) above what was measured; the measured number lies below the stated range.
By their numbers in this assay, from the lowest: compound 4; then compound 1; then compound 2. At a limit, above all of these: compound 3.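

Replacing the substituted phenyl on the sulfonyl sulfur with pyridin-2-yl gives a 5.7-fold lower number from compound 1 to compound 4 (0.75 log units; beyond the scatter), a 27-fold lower number from compound 2 to compound 4 (1.43 log units; beyond the scatter) and an at least 50-fold lower number from compound 3 to compound 4 (1.69 log units; beyond the scatter). This position can therefore lower the number as well as raise it, and compound 4, the only one of the four with a nitrogen in this ring, is the strongest inhibitor among them. The step from compound 3 rests on a limit, not a number: the limit of > 30000 nM in this assay, at which 1 of the 4 values shown sits.

The compounds shown leave open whether the ring nitrogen matters, or the absence of a ring substituent, and whether the nitrogen's place in the ring counts. A plain phenyl, pyridin-3-yl or pyridin-4-yl on the same sulfur would address this.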